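The compounds below may be only part of what the source reports. "The series", "measured", "known", "first", "only" and "open" are said of these compounds alone.

Compounds measured so far:
compound 1 `CS(=O)(=O)c1c(CCc2ccccc2)c2cc(OCC(=O)NCC3CC3)ccc2[nH]c1=O` — in a functional assay on CHO cells for antagonist activity at adenosine receptor A2b (Homo sapiens), read by cAMP accumulation, with stated times of 15 min and 1 h (on this read-out higher numbers stand for weaker inhibition and lower numbers for stronger inhibition), compound 1 gives > 5000 nM, which is a limit of the assay and not a number.
compound 2 `Cc1cc(-c2c(CCc3ccccc3)c3cc(OCC(=O)NC(C)(C)c4ccccc4)ccc3[nH]c2=O)on1` — in this assay compound 2 gives 31 nM.
compound 3 `CS(=O)(=O)c1c(CCc2ccccc2)c2cc(OCC(=O)Nc3ccccc3)ccc2[nH]c1=O` — in this assay compound 3 gives 1680 nM.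

Among the two compounds that gave a number, compound 3 stands at the higher end, with compound 2 well beyond the scatter below it; compound 1 reached only the limit of the assay. The next compound, compound 4 `CN(Cc1ccc(Cl)c(Cl)c1)C(=O)COc1ccc2[nH]c(=O)c(S(C)(=O)=O)c(CCc3ccccc3)c2c1`, differs from compound 3 in one place: (3,4-dichlorobenzyl)(methyl)amino in place of anilino on a carbonyl carbon. The amide hydrogen of compound 3 is thus lost, and a larger group with two chlorines takes the place of the plain phenyl.

Going by the values given here, one measured step touches the same amide nitrogen: an at least 2.9-fold lower number from compound 1 to compound 3 (0.47 log units; beyond the scatter). Compound 2 carries a bulkier, phenyl-bearing amide substituent and gives the lowest number shown, though no single step links it to compound 3. Taken together, changes at this nitrogen have moved the numbers in this assay by modest to large amounts, but none of them removed the amide hydrogen, so the direction for compound 4 is open. The expectation for compound 4 is therefore a step of a 1.9-fold lower number from compound 3 to compound 4 (0.27 log units; within the scatter), with wide uncertainty. Compound 4 is estimated at 900 nM, within 200 nM to 4000 nM.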

Compound 4, inhibition constant: 1020 nM
Compound 4: the middle estimate sits 1.1-fold (0.05 log units) below what was measured; low and high end bracket the measured number.
By their numbers in this assay, from the lowest: compound 2; then compounds 4 and 3 (each within the scatter of the next). At a limit, above all of these: compound 1.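

In this assay, the amide hydrogen of compound 3 is lost and the larger (3,4-dichlorobenzyl)(methyl)amino group replaces anilino on the carbonyl carbon, yet the number does not move beyond the scatter (a 1.6-fold lower number from compound 3 to compound 4 (0.22 log units; within the scatter)). So this position accepts a nitrogen with no hydrogen on it and a much larger group without a clear gain or loss, which the earlier steps, all between amides that keep that hydrogen, could not show. As far as these compounds go, replacing the (cyclopropylmethyl)amino group of compound 1 gives a change beyond the scatter (an at least 4.9-fold lower number from compound 1 to compound 4 (0.69 log units; beyond the scatter)), and its true size is unknown, as the value of compound 1 is a limit and not a number: the limit of > 5000 nM in this assay, at which 1 of the 4 values shown sits.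

Because two things change at once in compound 4, the compounds shown cannot say what the lost hydrogen and the added chlorines each contribute, and the two effects could even cancel. A methylanilino group, which removes only the hydrogen, and a 3,4-dichlorobenzylamino group, which keeps it, would pull these two changes apart.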